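Nitro to Amino: Expected Cytotoxicity of Compound 4

The source may report more compounds than this note shows. Statements on the series, on what has been measured and on what is new or still open speak of the compounds shown alone.

The compounds here were tested in a functional assay on B16 cells (Mus musculus) for cytotoxicity, read by MTT assay, with a stated time of 3 days; a higher number here means a weaker inhibitor, a lower number a stronger inhibitor. Compound 1 `COc1ccc(C(=O)/C=C/c2cc(OC)c(OC)c(OC)c2)cc1[N+](=O)[O-]` carries a nitro group. In this assay compound 1 gives > 100000 nM, which is a limit of the assay rather than a number. Compound 2 `COc1ccc(C(=O)/C=C/c2cc(OC)c(OC)c(OC)c2)cc1N` differs from it by amino in place of nitro on an aromatic carbon. In this assay compound 2 gives 67000 nM. That change produced an at least 1.4-fold lower number from compound 1 to compound 2 (0.17 log units; that floor lies within the scatter). The step is only a floor, since it rests on (the limit of > 100000 nM in this assay, at which 2 of the 3 values shown sit).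

Compound 3 `COc1cc(C(=O)/C=C/c2ccc([N+](=O)[O-])cc2)cc(OC)c1OC` is built on a different core; how the core of compound 3 differs from the core of compound 1 is not broken down here. In this assay compound 3 gives > 100000 nM, again a limit of the assay and not a number.

Compound 4 `COc1cc(C(=O)/C=C/c2ccc(N)cc2)cc(OC)c1OC` is still to be measured. It differs from compound 3 by amino in place of nitro on an aromatic carbon. The surroundings are not the same: in compound 2 the amino sits ortho to a methoxy group and meta to a large group, whereas in compound 4 it sits para to a large group, so this is the same kind of change, not the same change. Because the earlier step of an at least 1.4-fold lower number from compound 1 to compound 2 (0.17 log units; that floor lies within the scatter) is a floor set by a limit, and compound 3 also sits at a limit, the expected step is an at least 1.6-fold lower number from compound 3 to compound 4 (0.22 log units; that floor lies within the scatter). Compound 4 is estimated at 60000 nM, with a range from 20000 nM to 150000 nM, and a real chance that only a limit is reported.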

Compound 4, half-maximal inhibitory concentration: 30000 nM
The estimate for compound 4 lay 2.0-fold (0.30 log units) above the measured number; the range from low to high includes it.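

In this assay, amino in place of nitro on an aromatic carbon gives an at least 3.3-fold lower number from compound 3 to compound 4 (0.52 log units; beyond the scatter), so on this core the change clears the usual scatter, while the earlier floor on the core of compound 1, an at least 1.4-fold lower number from compound 1 to compound 2 (0.17 log units; that floor lies within the scatter), does not. Both steps point the same way, and the amino group has different surroundings on the two cores, but it stays undecided whether the change is worth more on one core than on the other: the same change on two cores in this assay, an at least 1.4-fold lower number (0.17 log units; that floor lies within the scatter) from compound 1 to compound 2 and an at least 3.3-fold lower number (0.52 log units; beyond the scatter) from compound 3 to compound 4; the limit leaves it open whether they differ. Each step is only a floor, since each nitro compound gives a limit of the assay and not a number, so the true size of neither step is known: the limit of > 100000 nM in this assay, at which 2 of the 4 values shown sit.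

The compounds shown leave open what other groups would do in the place of the amino group on either core, for example a hydroxyl, a methylamino or an acetamide. They also leave open whether the gain follows the amino group itself or appears only with certain surroundings, which would take the amino and nitro groups at matching places on a single core.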